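Fluoro in place of methyl on the six-membered ring

A few compounds are considered here, and "the series" means these few. Any claim that something is new, unique, unknown or untested is made for them only; others in the source may bear on it.

Measured so far:
compound 1 `Cc1ccncc1-c1nc2cc(F)c(F)cc2n1C1CC1` — 723 nM
compound 2 `Cc1cncc(-c2nc3cc(F)c(F)cc3n2C2CC2)c1C` — 17.7 nM
compound 3 `Cc1c(F)cncc1-c1nc2cc(F)c(F)cc2n1C1CC1` — not yet measured

In an assay on V79 cells for inhibition of cytochrome P450 11B1, mitochondrial (Homo sapiens), read by HTRF, with a stated time of 1 h (a higher number here means a weaker inhibitor, a lower number a stronger inhibitor), compound 1 gives 723 nM and compound 2 gives 17.7 nM. Among the compounds with values here, the single measured step, a 41-fold lower number from compound 1 to compound 2 (1.61 log units; beyond the scatter), is the only information on substituent changes on the six-membered aromatic ring with 1 nitrogen. Compound 2 therefore stands as the lowest of the two numbers, with compound 1 far higher, beyond the scatter.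

Compound 3 differs from compound 2 by fluoro in place of methyl on an aromatic carbon. The methyl that leaves is the one whose introduction gave the large step from compound 1 to compound 2. Within the data shown here, no measured pair shows what a fluoro at this position does, so the step can only be bracketed: removing the methyl points back toward compound 1, while the entering fluoro is an unknown that could hold part of the gain. The expectation is for a number higher than compound 2 but not as high as compound 1, with wide uncertainty.

Compound 3 is expected to give about 90 nM in this assay, plausibly between 25 nM and 350 nM. The estimated step is a 5.1-fold higher number from compound 2 to compound 3 (0.71 log units; beyond the scatter).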

Compound 3, half-maximal inhibitory concentration: 258 nM
Estimate against measurement, compound 3: 2.9-fold (0.46 log units) below, and the stated range covers the measured number.
By their numbers in this assay, from the lowest: compound 2; then compound 3; then compound 1.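

In this assay, this aromatic carbon now has three measured substituents, and replacing methyl with fluoro gives a 15-fold higher number from compound 2 to compound 3 (1.16 log units; beyond the scatter) even though the heavy-atom count is unchanged, so the gain seen with methyl does not extend to every single-atom substituent at this carbon. Fluoro is nevertheless not equivalent to hydrogen here: it gives a 2.8-fold lower number from compound 1 to compound 3 (0.45 log units; beyond the scatter) and so retains a modest part of the gain, against a 41-fold lower number from compound 1 to compound 2 (1.61 log units; beyond the scatter) for methyl. Nothing available explains the difference between methyl and fluoro at this carbon.

As far as these compounds go, it remains open whether a chloro, an ethyl, a methoxy, a trifluoromethyl or an amine on this aromatic carbon would give a number nearer to that of compound 2 or to that of compound 1, and three substituents do not establish a trend across such groups. From the compounds shown here alone, the methyl group ortho to this carbon is constant across all three compounds, so the size of these steps in its absence also remains unknown.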